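The source may hold more compounds than are shown below. What is called first, only, known or untested is meant among the compounds shown, and "the series" means these compounds.

Compound 1 `Fc1ccc(OCC2=NCCO2)cc1`: 75.5 mg/kg
Compound 2 `O=[N+]([O-])c1ccccc1OCC1=NCCO1`: 70.1 mg/kg
Compound 3 `O=[N+]([O-])c1ccc(OCC2=NCCO2)cc1`: 60.5 mg/kg

All three were tested in a functional assay on the whole organism for inhibition, with Rattus norvegicus as the target, read by paw edema, with a stated time of 30 min; on this read-out higher numbers stand for an effect only at larger amounts of compound and lower numbers for an effect already at smaller amounts. Compound 3 gives 60.5 mg/kg, and compound 1 gives 75.5 mg/kg; the change from one to the other, (fluoro in place of nitro on an aromatic carbon), made a step of a 1.2-fold higher number from compound 3 to compound 1 (0.10 log units; within the scatter). Compound 2 gives 70.1 mg/kg. How the core of compound 2 differs from that of compound 3 is not broken down here.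

The not yet measured compound 4 `Fc1ccccc1OCC1=NCCO1` arises from compound 2 by fluoro in place of nitro on an aromatic carbon. This is the same kind of change as that from compound 3 to compound 1, though the place differs: in compound 4 the fluoro sits ortho to a group of 7 heavy atoms, in compound 1 para to a group of 7 heavy atoms. For compound 4 a step of about a 1.2-fold higher number from compound 2 to compound 4 (0.07 log units; within the scatter) is expected, resting on the earlier step of a 1.2-fold higher number from compound 3 to compound 1 (0.10 log units; within the scatter). Compound 4 is therefore estimated at 82 mg/kg, with a likely range from 55 mg/kg to 125 mg/kg.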

Compound 4, dose for half-maximal effect: 76.2 mg/kg
For compound 4 the middle estimate is 1.1-fold (0.03 log units) above the measured one; low and high end bracket the measured number.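

In this assay, fluoro in place of nitro on an aromatic carbon gives a 1.1-fold higher number from compound 2 to compound 4 (0.04 log units; within the scatter). Set beside the earlier step, the change behaves alike on both cores: the same change on two cores in this assay, a 1.2-fold higher number (0.10 log units; within the scatter) from compound 3 to compound 1 and a 1.1-fold higher number (0.04 log units; within the scatter) from compound 2 to compound 4, 1.1-fold (0.06 log units) apart, within the scatter of two such steps. For the compounds shown here, both steps lie within the scatter, so this shows only that the change makes no clear difference on either of these two cores; it does not show that a clear effect would carry from one core to another, or that the same would hold on any further core.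

The compounds shown leave open how an amine, a carboxylic acid or a longer chain would read on that aromatic carbon. They also leave open whether any group there moves the number beyond the scatter.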